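A few compounds are considered here, and "the series" means these few. Any claim that something is new, unique, unknown or untested is made for them only; others in the source may bear on it.

Of the compounds shown here, two built on one shared core have been tested in a functional assay on MCF7 cells (Homo sapiens) for inhibition, read by MTT assay, with a stated time of 72 h; a lower number here means a stronger inhibitor, a higher number a weaker inhibitor. Compound 1 `CN(C(=O)NC(=O)c1ccccc1F)c1nc(C(F)(F)F)c(C(=O)N/N=C/c2ccc(C(F)(F)F)cc2)s1` gives 4.98 ug/mL in this assay. Compound 2 `CN(C(=O)NC(=O)c1c(F)cccc1F)c1nc(C(F)(F)F)c(C(=O)N/N=C/c2cc(C(F)(F)F)cc(C(F)(F)F)c2)s1` gives 6.85 ug/mL in this assay. Among the measured compounds shown here, these two numbers lie within the usual scatter of each other, so compound 2 cannot be told apart from compound 1 on this evidence, and because the two compounds differ in more than one place, no single step between measured compounds has yet been seen.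

Compound 3 `CN(C(=O)NC(=O)c1c(F)cccc1F)c1nc(C(F)(F)F)c(C(=O)N/N=C/c2cccc(C(F)(F)F)c2)s1` has not yet been measured in this assay. Against compound 2 it shows (hydrogen in place of trifluoromethyl on an aromatic carbon). The step expected from this change, a 1.2-fold lower number from compound 2 to compound 3 (0.10 log units; within the scatter), is estimated to be small, leaning toward a lower number but not beyond the scatter, because compound 1, which also carries a single trifluoromethyl on that ring, gives 4.98 ug/mL. Compound 3 is therefore expected to give about 5.5 ug/mL in this assay, with a likely range from 2.5 ug/mL to 12 ug/mL.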

Compound 3, half-maximal inhibitory concentration: 21.8 ug/mL
Estimate against measurement, compound 3: 4.0-fold (0.60 log units) below; the measured number lies above the stated range.
By their numbers in this assay, from the lowest: compounds 1 and 2 (each within the scatter of the next); then compound 3.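

In this assay, among the compounds shown here, replacing one trifluoromethyl on the aromatic ring with hydrogen gives a 3.2-fold higher number from compound 2 to compound 3 (0.50 log units; beyond the scatter), the first change in a single place that can be read in this set. What sits on this aromatic carbon, meta to a trifluoromethyl group, therefore matters to the measured number: in this pair, the compound that keeps the trifluoromethyl there is the stronger inhibitor. This rests on one pair of compounds, so it cannot yet stand as a rule for the series. Nothing measured here gives a reason for the step.

The compounds shown leave open whether the trifluoromethyl itself is needed at this carbon, or whether another group in place of hydrogen, such as a chlorine atom, a methyl group or a methoxy group, would give a number closer to that of compound 2. They also leave open whether the same exchange would give a similar step on a compound carrying a different benzoyl group on the other side of the shared core.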